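Swapping a Hydroxy for a Methyl: Predicting Compound 4

This account rests on a few compounds, and the source may have more. Where it says the series, first, only, none or still open, it means among the compounds named here.

Measured so far in a functional assay on HepG2 cells (Homo sapiens) for inhibition, read by MTT assay, with a stated time of 72 h; a lower number here means a stronger inhibitor, a higher number a weaker inhibitor:
compound 1, `Cc1ccc2nc(-c3ccc(NCc4cn(Cc5cc(=O)oc6cc(O)ccc56)nn4)cc3)sc2c1`, gives 52800 nM
compound 2, `Cc1ccc2c(Cn3cc(CNc4ccc(-c5nc6ccc(C)cc6s5)cc4)nn3)cc(=O)oc2c1`, gives 94700 nM
compound 3, `O=c1cc(Cn2cc(-n3ccc4cc(I)ccc43)nn2)c2ccc(O)cc2o1`, gives 8570 nM

Compounds 1 and 2 share a core and differ in one place, (methyl in place of hydroxy on an aromatic carbon). In this assay the step is a 1.8-fold higher number from compound 1 to compound 2 (0.25 log units; within the scatter), so the two numbers cannot be told apart with confidence. Compound 3 is built on a different core; how its core differs from that of compound 1 is not broken down here. Compound 3 has the lowest number of the three, and its distance to compound 1 and to compound 2 is beyond the scatter.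

Compound 4, `Cc1ccc2c(Cn3cc(-n4ccc5cc(I)ccc54)nn3)cc(=O)oc2c1`, is not yet measured. It differs from compound 3 in one place, (methyl in place of hydroxy on an aromatic carbon), the same change as that between compound 1 and compound 2. Because the same change gave a 1.8-fold higher number from compound 1 to compound 2 (0.25 log units; within the scatter) in this assay, the step from compound 3 to compound 4 is expected to be of a similar small size, a 1.8-fold higher number from compound 3 to compound 4 (0.24 log units; within the scatter). For compound 4 the expected value in this assay is 15000 nM, estimated to fall between 6000 nM and 40000 nM.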

Compound 4, half-maximal inhibitory concentration: 38100 nM
Compound 4: middle estimate off by 2.5-fold (0.40 log units), on the low side; low and high end bracket the measured number.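

In this assay, putting a methyl in place of the hydroxy gives a 4.4-fold higher number from compound 3 to compound 4 (0.65 log units; beyond the scatter) on the core of compound 3. Set beside the same change on the core of compound 1, the two steps cannot be told apart with confidence, so the data fit a single modest step shared by both cores: the same change on two cores in this assay, a 1.8-fold higher number (0.25 log units; within the scatter) from compound 1 to compound 2 and a 4.4-fold higher number (0.65 log units; beyond the scatter) from compound 3 to compound 4, 2.5-fold (0.39 log units) apart, within the scatter of two such steps. For the compounds shown here, this does not show that the step has one fixed size, since two cores are a small sample and only the step on the core of compound 3 lies clear of the scatter by itself.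

The compounds shown leave open how other groups at this place on the aromatic carbon would compare with the hydroxy and the methyl, for example a methoxy group, an amine or a carboxylic acid. They also leave open whether the swap of hydroxy for methyl would give a step of similar size on any further core in this series.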